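The source may report more compounds than this note shows. Statements on the series, on what has been measured and on what is new or still open speak of the compounds shown alone.

Working notes on the series, read in an assay on MDA-MB-231 cells for binding affinity to C-X-C chemokine receptor type 4 (Homo sapiens), read by immunofluorescence and microscopy, with stated times of 10 min and 30 min; a higher number here means that more compound is needed for the effect, a lower number that less compound is needed.

Compound 1 `O=C(NCc1ccc(CNS(=O)(=O)c2ccccc2)cc1)c1cccc(F)c1` gives 100 nM. Among the measured compounds shown here, compound 3 `O=C(NCc1ccc(CNS(=O)(=O)c2ccccc2)cc1)c1ccc(F)cc1` gives 100 nM; the one single-point step measured so far, no change at the digits printed from compound 1 to compound 3 (within the scatter), stays within the scatter. Compound 2 `Cc1ccc(S(=O)(=O)NCc2ccc(CNC(=O)c3ccc([N+](=O)[O-])cc3)cc2)cc1` stands lowest of the three with 10 nM, and its distance to compound 1 and to compound 3 lies beyond the scatter in both cases. Compound 2 differs from each of those two in more than one place, so the measured values alone cannot say which part of the structure carries that difference.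

Compound 4 `COc1ccc(C(=O)NCc2ccc(CNS(=O)(=O)c3ccc(C)cc3)cc2)cc1` follows from compound 2 by a single change: methoxy in place of nitro on an aromatic carbon. For the measured compounds named here, no measured step bears on this change. Going by the values given here, the only step on record, no change at the digits printed from compound 1 to compound 3 (within the scatter), concerns the fluorophenyl on the carbonyl carbon and speaks to a different exchange. The comparison of compound 2 with compound 1 or compound 3 is not a guide either, since more than one group differs there. Without precedent, the number for compound 4 in this assay is expected to rise somewhat, by a step of about a 3.0-fold higher number from compound 2 to compound 4 (0.48 log units; beyond the scatter), while a change no larger than the scatter remains possible. Compound 4 is therefore estimated at 30 nM, with a range from 10 nM to 100 nM.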

Compound 4, effective concentration (reported as EC, without a stated level of effect): 100 nM
Estimate against measurement, compound 4: 3.3-fold (0.52 log units) below; the measured number falls inside the stated range.
By their numbers in this assay, from the lowest: compound 2; then compounds 1, 3 and 4 (each within the scatter of the next).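

In this assay, among the compounds shown here, methoxy in place of nitro on the aromatic carbon gives a 10-fold higher number from compound 2 to compound 4 (1.00 log units; beyond the scatter) and is the first single change to move the number beyond the scatter. For the compounds shown here, the only earlier single change, no change at the digits printed from compound 1 to compound 3 (within the scatter) for 4-fluorophenyl in place of 3-fluorophenyl on a carbonyl carbon, gave no such sign, whereas this step shows that, on the core of compound 2, the number responds to the group on this aromatic carbon para to a large group. No measurement at hand gives a reason for the size of this step, so it stands as an observation only.

With only nitro and methoxy read at this place on this core, the compounds shown do not tell whether other groups, such as a nitrile, an amine or a carboxylic acid, would stay with nitro, stay with methoxy or fall elsewhere. They also leave open whether the same exchange would give a step of similar size on the core of compound 1, where the methyl group on the sulfonyl-bearing ring is absent and the carbonyl-bearing ring carries fluorine instead.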